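This account rests on a few compounds, and the source may have more. Where it says the series, first, only, none or still open, it means among the compounds named here.

Measured compounds and their values in an assay on isolated protein for binding affinity to leukotriene B4 receptor 1 (Homo sapiens), tested at 1 uM; on this read-out higher numbers stand for more inhibition at the one concentration tested (going by the name of the read-out) and lower numbers for less inhibition:
compound 1 `CCCCc1cc(C(C)=O)c(O)cc1OCCCCC#N` gives 13%
compound 2 `C=CCc1cc(C(C)=O)c(O)cc1OCCCCCCCCCCC#N` gives 14%
compound 3 `CCc1cc(C(C)=O)c(O)cc1OCCCCCC(C)(C)c1nnn(C)n1` gives 66%

Three compounds share a core, and the chain attached to the aromatic oxygen varies. Compound 2 stands second highest of the three numbers; its nearest neighbour is compound 1, whose value lies within the scatter of it, so the two cannot be told apart. Compound 3 stands far above both, beyond the scatter.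

The step from compound 2 to the unmeasured compound 4 `C=CCc1cc(C(C)=O)c(O)cc1OCCCCCC(C)=O` is this: acetyl in place of 5-cyanopentyl on a saturated chain carbon, five bonds along the chain from an oxygen on an aromatic ring. Within the data shown here, no pair of measured compounds shows this exact change, so the step must be judged from the structures alone. Because compound 2 gives 14% with its 5-cyanopentyl chain, and compound 1 with a shorter nitrile chain gives 13%, a shortened chain ending in an acetyl is expected to move this assay little, most likely by no more than the scatter, in either direction. For compound 4 the expected value is 15%, ranging from 4% to 35%. The estimated step from compound 2 to compound 4 is therefore a number 1 percentage points higher from compound 2 to compound 4 (within the scatter).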

Compound 4, a percentage reported as inhibition, at one concentration (the size of the read-out at that concentration, not a potency): 58%
Compound 4: the middle estimate sits 43 percentage points below what was measured, and the stated range ends below it.
By their numbers in this assay, from the lowest: compounds 1 and 2 (each within the scatter of the next); then compounds 4 and 3 (each within the scatter of the next).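

In this assay, among these compounds, placing acetyl where 5-cyanopentyl stood, on a saturated chain carbon five bonds along the chain from an oxygen on an aromatic ring, gives a number 44 percentage points higher from compound 2 to compound 4 (beyond the scatter) and is the first one-place comparison here, showing that this read-out responds strongly to what stands at this position. The group that leaves has 7 heavy atoms and the group that enters has 3, yet each has 1 hydrogen-bond acceptor and no hydrogen-bond donor, so those counts do not separate the two compounds. Nothing shown gives a reason for this rise.

This single step changes both the chain length and the chain end, so their shares remain unresolved. From the compounds shown here alone, a nitrile on the shorter chain of compound 4, or a longer chain ending in acetyl, would separate the two, and a carboxylic acid or an amine at this chain end remains open.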